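Swapping the dichlorobenzyl for a cyanobenzyl: cytotoxicity outlook

The compounds below may be only part of what the source reports. "The series", "measured", "known", "first", "only" and "open" are said of these compounds alone.

Measured compounds:
compound 1, `O=C1N(Cc2ccc(Cl)cc2Cl)c2cccn2S(=O)(=O)N1Cc1ccccc1`, 218000 nM
compound 2, `O=C1N(Cc2ccc(Cl)cc2Cl)c2cccn2S(=O)(=O)N1Cc1cccc(Cl)c1`, > 251000 nM

For the measured compounds named here, compound 1 has the only numerical value in an ADME assay on MT4 cells (Homo sapiens) for cytotoxicity, read by MTT assay, with a stated time of 5 days; on this read-out lower numbers stand for higher toxicity in this test and higher numbers for lower toxicity in this test: compound 1 gives 218000 nM. Compound 2 is reported only as a limit of this assay, > 251000 nM; this is the limit of > 251000 nM in this assay, at which 1 of the 2 values shown sits. Going by the values given here, the one measured step, an at least 1.1-fold higher number from compound 1 to compound 2 (0.06 log units; that floor lies within the scatter), sits within the scatter at its floor.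

Compound 3 is `N#Cc1cccc(CN2C(=O)N(Cc3ccccc3)S(=O)(=O)n3cccc32)c1`. It differs from compound 1 by 3-cyanophenyl in place of 2,4-dichlorophenyl on a saturated chain carbon bound to an amide-type nitrogen in a ring. Among the compounds with values here, that change shares nothing with the measured step, so it gives no direction of its own; the one measured step also stayed within the scatter. The step of a 1.1-fold higher number from compound 1 to compound 3 (0.02 log units; within the scatter) is therefore expected to lie within the scatter. For compound 3 the expected value in this assay is 230000 nM, ranging from 110000 nM to 500000 nM, with a real chance that only a limit is reported.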

Compound 3, half-maximal cytotoxic concentration: > 318000 nM
Compound 3 was reported as a limit (the forecaster's own chance of this, stated with the estimate: 50%); middle value at least 1.3-fold (0.14 log units) away from the limit.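

In this assay compound 3 is reported only as a limit, > 318000 nM. For the compounds shown here, replacing 2,4-dichlorobenzyl with 3-cyanobenzyl on the saturated chain carbon bound to an amide-type nitrogen in a ring gives an at least 1.4-fold higher number from compound 1 to compound 3 (0.16 log units; that floor lies within the scatter); this position, left unchanged in the earlier compounds, thus tolerates losing both chlorines and gaining a nitrile with no fall in the number. Compound 3 gives no exact size for this change: the limit of > 318000 nM in this assay, at which 1 of the 3 values shown sits.

The compounds shown leave open whether the loss of the chlorines or the entry of the nitrile governs this result, as both change in the one step. They also leave open whether an amine or a carboxylic acid on this benzyl ring would keep the number at this level.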